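A few compounds are considered here, and "the series" means these few. Any claim that something is new, unique, unknown or untested is made for them only; others in the source may bear on it.

Measured so far:
compound 1 `COc1ccc(-c2c(C#N)c(N)c(C#N)c(SC)c2-c2ccccc2)cc1`; in an assay on isolated protein for inhibition of glucose-6-phosphatase catalytic subunit 1 (Homo sapiens), tested at 100 uM (a lower number here means less inhibition, a higher number more inhibition at the concentration tested (going by the name of the read-out)), compound 1 gives 6.8%
compound 2 `COc1ccc(-c2c(C#N)c(N)c(C#N)c(SC)c2-c2ccc(OC)cc2)cc1`; in this assay compound 2 gives 5.5%

Within the data shown here, compound 2 and compound 1 sit within the scatter of each other in this assay; the one measured step, a number 1.3 percentage points lower from compound 1 to compound 2 (within the scatter), is within the scatter. Compound 3 `COc1ccc(-c2c(C#N)c(N)c(C#N)c(SC)c2-c2ccc(F)cc2)cc1` is not yet measured. fluoro in place of methoxy on an aromatic carbon The step of a number 1.3 percentage points lower from compound 1 to compound 2 (within the scatter) also concerns a substituent on an aromatic carbon and bears on this change; it gives no sign of a step beyond the scatter. No step beyond the scatter is therefore expected in this assay. Compound 3 is estimated at 6%, range 0% to 14%. The expected step is a number 0.5 percentage points higher from compound 2 to compound 3 (within the scatter).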

Compound 3, a percentage reported as inhibition, at one concentration (the size of the read-out at that concentration, not a potency): 5.5%
Estimate against measurement, compound 3: 0.5 percentage points above, within the range that was stated.
By their numbers in this assay, from the lowest: compounds 2, 3 and 1 (each within the scatter of the next).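

In this assay, fluoro in place of methoxy gives no change at the digits printed from compound 2 to compound 3 (within the scatter), and fluoro in place of hydrogen gives a number 1.3 percentage points lower from compound 1 to compound 3 (within the scatter). Hydrogen, methoxy and fluoro on this aromatic carbon, para to a large group, therefore all lie within the scatter of one another, so a second substituent type has now been seen here without a step beyond the scatter. Nothing available explains why these three numbers stay together.

Going by these compounds, it remains open whether an amine or a carboxylic acid at this place would give a step beyond the scatter. On these data alone, the effect of changes elsewhere on the shared core also remains open.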